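Swapping Two Ring Substituents on the Urea End

The compounds below may be only part of what the source reports. "The series", "measured", "known", "first", "only" and "open" are said of these compounds alone.

Compound 1 `CC(NC(=O)/C=C/c1ccc(NC(=O)Nc2ccc(Cl)c(C(F)(F)F)c2)cc1)c1ccccc1`: 1060 nM
Compound 2 `CNC(=O)/C=C/c1ccc(NC(=O)Nc2ccc(Cl)c(C(F)(F)F)c2)cc1`: 11700 nM
Compound 3 `CC1CN(C(=O)/C=C/c2ccc(NC(=O)Nc3ccc(Cl)c(C(F)(F)F)c3)cc2)CC(C)O1`: 9100 nM

Of the compounds shown here, three sharing one core have been tested in a functional assay on HT-29 cells (Homo sapiens) for inhibition, read by MTT assay, with a stated time of 120 h; on this read-out lower numbers stand for stronger inhibition and higher numbers for weaker inhibition. Compound 1 gives the lowest number of the three. Its nearest neighbour is compound 3, reached by an 8.6-fold higher number from compound 1 to compound 3 (0.93 log units; beyond the scatter); the furthest is compound 2, reached by an 11-fold higher number from compound 1 to compound 2 (1.04 log units; beyond the scatter). Between compound 2 and compound 3 the step is a 1.3-fold lower number from compound 2 to compound 3 (0.11 log units; within the scatter), which is within the scatter, so those two cannot be ranked.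

Compound 4 `CC(NC(=O)/C=C/c1ccc(NC(=O)Nc2cc(C(F)(F)F)ccc2Cl)cc1)c1ccccc1` has not been measured. It differs from compound 1 by 2-chloro-5-(trifluoromethyl)phenyl in place of 4-chloro-3-(trifluoromethyl)phenyl on an amide-type nitrogen. The same atoms are present; only the arrangement of the chlorine and trifluoromethyl on that ring changes. Within the data shown here, every measured step so far altered the amide end of the core, not the urea-bearing ring, so none of them bears on this change, and the direction cannot be read from the data. As a cautious guess, compound 4 is expected to give 3000 nM, somewhere between 700 nM and 13000 nM. The expected step from compound 1 to compound 4 is therefore a 2.8-fold higher number from compound 1 to compound 4 (0.45 log units; beyond the scatter).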

Compound 4, half-maximal inhibitory concentration: 4190 nM
Estimate against measurement, compound 4: 1.4-fold (0.15 log units) below; the range from low to high includes it.
By their numbers in this assay, from the lowest: compound 1; then compound 4; then compounds 3 and 2 (each within the scatter of the next).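

Rearranging the chlorine and trifluoromethyl on the phenyl ring, with no atom gained or lost, still changes the result in this assay, giving a 4.0-fold higher number from compound 1 to compound 4 (0.60 log units; beyond the scatter). Among these compounds, the earlier steps all altered the amide end, so this is the first sign that the aryl group on the urea also affects the number, and 4-chloro-3-(trifluoromethyl)phenyl gives the lower number of these two arrangements. Nothing available explains this difference.

The compounds shown test this rearrangement only with the 1-phenylethyl amide, so its effect alongside the methyl amide of compound 2 or the 2,6-dimethylmorpholin-4-yl amide of compound 3 remains open. Also open, on these data alone, is how this ring would fare with a nitrile or a methoxy group in place of the chlorine.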